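One Added Methyl on the Acid Side Chain

The source may hold more compounds than are shown below. What is called first, only, known or untested is meant among the compounds shown, and "the series" means these compounds.

- Compound 1 `O=C(O)Cc1nn(Cc2cn3cc(OCC4CC4)c(Cl)cc3n2)c2ccccc2c1=O` gives < 6.67 mL/min/kg as a limit
- Compound 2 `C[C@H](C(=O)O)n1nc(Cn2cc3cc(OCC4CC4)c(Cl)cc3n2)c2ccccc2c1=O` gives < 10 mL/min/kg as a limit

Both entries come from an ADME assay on cells (Hepatocyte, Homo sapiens) for metabolic stability, read by LC-MS, with a stated time of 180 min, tested at 1 uM (a higher number here means faster removal of the compound, a lower number slower removal), and both are limits, not numbers. Compound 1 therefore has no exact place on the scale, and the value for compound 2 offers no exact figure to compare it with. For the measured compounds named here, no two measured compounds here differ in just one place, so no measured step can serve as a guide.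

The next compound to be tested is compound 3 (`C[C@H](C(=O)O)c1nn(Cc2cn3cc(OCC4CC4)c(Cl)cc3n2)c2ccccc2c1=O`). It keeps the core of compound 1 and makes one change (methyl in place of hydrogen on a saturated chain carbon bound to an aromatic carbon and a carbonyl carbon), with methyl in place of hydrogen on a saturated chain carbon bound to an aromatic carbon and a carbonyl carbon. Carboxymethyl thus becomes 1-carboxyethyl.

In this assay no change beyond the usual scatter is expected, in either direction, so the estimated step that the limit leaves unreadable from compound 1 to compound 3 stays small. The result may again arrive only as a limit. For compound 3 the estimate is 6 mL/min/kg with an expected range from 2.5 mL/min/kg to 12 mL/min/kg in this measurement.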

Compound 3, clearance: 6.67 mL/min/kg
Beside the measured number, compound 3's estimate is 1.1-fold (0.05 log units) below it, and the stated range covers the measured number.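

In this assay compound 3 gives 6.67 mL/min/kg, the first exact number among the compounds shown, so the series now has a firm point on the scale. Methyl in place of hydrogen on the saturated chain carbon bound to an aromatic carbon and a carbonyl carbon, which turns carboxymethyl into 1-carboxyethyl, gives a number no lower from compound 1 to compound 3 (the limit leaves the size open). The direction of this step is all that can be said, and its size cannot be read because the entry for compound 1 is a limit, not a number: the limit of < 6.67 mL/min/kg in this assay, at which 1 of the 3 values shown sits.

With a single step, and one of unknown size, the compounds shown say nothing general about how changes at this chain carbon affect removal of the compound in hepatocytes. For the compounds shown here, it stays open how a larger group on this carbon, such as an ethyl or a second methyl, would compare with compound 3, and whether an amide in place of the carboxylic acid would give a number in this assay that can be set directly against the one for compound 3.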